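The source may report more compounds than this note shows. Statements on the series, on what has been measured and on what is new or still open speak of the compounds shown alone.

Working notes on the series

Of the compounds shown here, two of this set have been measured; both carry the shared core of compound 2 `CCn1nc(-c2nccs2)c2ccccc2c1=O`. In an assay on isolated protein (Oryctolagus cuniculus) with Thromboxane-A synthase (Homo sapiens) as the target, tested at 1 uM (a higher number here means more inhibition at the concentration tested (going by the name of the read-out), a lower number less inhibition), compound 2 gives 4%. Compound 1 `CCn1nc(-n2cncn2)c2ccccc2c1=O` gives 0% in this assay. Compound 2 thus holds the higher of the two numbers, but the step of a number 4 percentage points higher from compound 1 to compound 2 (within the scatter), so the two compounds are not separated by the measurement.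

Compound 3 `CCn1nc(-c2cncs2)c2ccccc2c1=O` has not yet been measured. Against compound 2 the change is 1,3-thiazol-5-yl in place of 1,3-thiazol-2-yl on an aromatic carbon. Going by the values given here, no measured pair shows this exact exchange; the only step at hand is a number 4 percentage points higher from compound 1 to compound 2 (within the scatter), which replaced one five-membered aromatic ring by another on the same aromatic carbon and left the number within the scatter. On that basis no step beyond the scatter is expected when moving to compound 3 in this assay. For compound 3 the expected step is a number 1 percentage points higher from compound 2 to compound 3 (within the scatter). Compound 3 is therefore estimated to give 5% in this assay, with a range from 0% to 20%.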

Compound 3, a percentage reported as inhibition, at one concentration (the size of the read-out at that concentration, not a potency): 77%
Compound 3: the middle estimate sits 72 percentage points below what was measured; the measured number lies above the stated range.
By their numbers in this assay, from the lowest: compounds 1 and 2 (each within the scatter of the next); then compound 3.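

In this assay this position, on an aromatic carbon of the shared core, responds not only to which ring is placed there but also to how that ring is joined: 1,3-thiazol-5-yl in place of 1,3-thiazol-2-yl, with the same atoms and the same counted donors and acceptors, gives a number 73 percentage points higher from compound 2 to compound 3 (beyond the scatter). The earlier pair left the two rings unseparated, whereas 1,3-thiazol-5-yl in place of 1H-1,2,4-triazol-1-yl gives a number 77 percentage points higher from compound 1 to compound 3 (beyond the scatter), so among these three groups only 1,3-thiazol-5-yl stands apart in this read-out. Nothing on hand accounts for the gap between the two thiazolyl attachments.

The compounds shown leave open whether a 1,3-thiazol-4-yl or a pyridin-3-yl group at this position would retain a number like that of compound 3, and whether a propyl chain in place of the ethyl group would do so. The read-out is taken at a single concentration, so it gives the size of the inhibition there and leaves the potency of compound 3 open.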